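The compounds below may be only part of what the source reports. "The series", "measured", "known", "first", "only" and "open" are said of these compounds alone.

Measured in a functional assay on the whole organism with Mus musculus as the target, in the maximal electroshock model; on this read-out lower numbers stand for an effect already at smaller amounts and higher numbers for an effect only at larger amounts of compound:
- compound 1 `Cn1c(=O)sc2ccccc21`: 24.2 mg/kg
- compound 2 `CCC(=O)c1ccc2c(c1)sc(=O)n2CCN1CCCC1`: 13.9 mg/kg
- compound 3 `CCCCC(=O)c1ccc2c(c1)sc(=O)n2CCN(C)C`: 27.3 mg/kg

Compound 3, at 27.3 mg/kg, lies within the scatter of both compound 1 and compound 2. Within the data shown here, no two measured compounds differ in only one place, so no direct step is available as a guide.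

Compound 4 `CCC(=O)c1ccc2c(c1)sc(=O)n2CCN(C)C` is the next to be read. Its difference from compound 3 is hydrogen in place of ethyl on a saturated chain carbon, two bonds along the chain from a carbonyl carbon. The same difference reads butylcarbonyl to propanoyl.

The propanoyl group of compound 4 also occurs in compound 2, which gives 13.9 mg/kg, although the two differ elsewhere. This supports only a slight lean towards a lower number in this assay. The expected step of a 1.4-fold lower number from compound 3 to compound 4 (0.14 log units; within the scatter) is small and not expected to exceed the scatter. For compound 4 the estimate is 20 mg/kg, with an expected range of 10 mg/kg to 38 mg/kg.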

Compound 4, dose for half-maximal effect: 21.8 mg/kg
The estimate for compound 4 lay 1.1-fold (0.04 log units) below the measured number; the range from low to high includes it.
By their numbers in this assay, from the lowest: compounds 2, 4, 1 and 3 (each within the scatter of the next).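

In this assay, among these compounds, going from butylcarbonyl to propanoyl gives the first direct step at this position (a 1.3-fold lower number from compound 3 to compound 4 (0.10 log units; within the scatter)), so hydrogen in place of ethyl on this saturated chain carbon does not move the number beyond the scatter. Among the compounds shown here, the first direct step on the amine end (a 1.6-fold higher number from compound 2 to compound 4 (0.20 log units; within the scatter)) likewise stays within the scatter, with dimethylamino in place of pyrrolidin-1-yl on a saturated chain carbon, two bonds along the chain from an aromatic nitrogen. No measurement on these compounds offers an explanation for either step.

On these data alone, whether a longer chain than butylcarbonyl, or a phenyl ketone in its place, would give a step beyond the scatter remains open. The same holds for a morpholin-4-yl or a piperidin-1-yl group in place of dimethylamino.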